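The source may report more compounds than this note shows. Statements on the series, on what has been measured and on what is new or still open speak of the compounds shown alone.

Compound 1 `CONC(=O)c1ccccc1O` — in an ADME assay on Huh-7 cells (Homo sapiens) for cytotoxicity, read by MTT assay, with a stated time of 72 h (on this read-out higher numbers stand for lower toxicity in this test and lower numbers for higher toxicity in this test), compound 1 gives > 800000 nM, which is a limit of the assay and not a number.
Compound 2 `Cc1ccccc1C(=O)NO` — in this assay compound 2 gives 650000 nM.
Compound 3 `Cc1cccc(C(=O)NO)c1` — in this assay compound 3 gives 340000 nM.

Compound 3 has the lowest of the two numbers reported; its nearest neighbour is compound 2, whose number is higher by an amount that stays within the scatter, so the two cannot be told apart. The third entry is a limit, one of the three values sitting at the limit of > 800000 nM in this assay, at which 1 of the 3 values shown sits.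

Compound 4 `COc1cccc(C(=O)NO)c1` differs from compound 3 in one place: methoxy in place of methyl on an aromatic carbon. Among the compounds with values here, no step between two measured compounds in this set shows what such a change does in this assay, so the only guide is the narrow spread of the numbers seen so far, all of which point to low toxicity. The step from compound 3 to compound 4 is therefore expected to be small, with no direction favoured beyond the scatter, namely a 1.2-fold higher number from compound 3 to compound 4 (0.07 log units; within the scatter). For compound 4 the estimated value in this assay is 400000 nM, expected to fall between 150000 nM and 1000000 nM.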

Compound 4, half-maximal cytotoxic concentration: 570000 nM
For compound 4 the middle estimate is 1.4-fold (0.15 log units) below the measured one; the measured number falls inside the stated range.
By their numbers in this assay, from the lowest: compounds 3, 4 and 2 (each within the scatter of the next). At a limit, above all of these: compound 1.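

Within the data shown here, this is the first step that can be read at this position, on an aromatic carbon meta to a group of 4 heavy atoms. In this assay, methoxy in place of methyl gives a 1.7-fold higher number from compound 3 to compound 4 (0.22 log units; within the scatter), so compound 3 and compound 4 cannot be told apart, even though the swap adds an oxygen and a hydrogen-bond acceptor. Nothing measured here bears on why the read-out stays within the scatter for this change.

The compounds shown leave open whether a different group at this same place, such as an amine, a carboxylic acid or a longer chain, would give a step beyond the scatter. They also leave open whether methoxy in place of methyl would give a similarly small step on another aromatic carbon of the ring.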